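Pyridyl Series: Compound 1 to Compound 4

The source may report more compounds than this note shows. Statements on the series, on what has been measured and on what is new or still open speak of the compounds shown alone.

Measured compounds:
- compound 1 `O[C@@H](c1ccccc1)[C@H]1CO[C@H](c2ccccc2)[C@@H](C/C=C/c2ccccn2)C1`: 33800 nM
- compound 2 `COc1ccc(/C=C/C[C@H]2C[C@@H]([C@@H](O)c3ccc(OC)c(OC)c3)CO[C@@H]2c2ccccc2)cc1OC`: 17000 nM
- compound 3 `COc1ccc(/C=C/C[C@@H]2C[C@@H]([C@@H](OC)c3ccc(OC)c(OC)c3)CO[C@H]2c2ccc(OC)c(OC)c2)cc1OC`: > 100000 nM

In a functional assay on HeLa cells (Homo sapiens) for cytotoxicity, read by WST assay, with a stated time of 48 h (a lower number here means a stronger inhibitor, a higher number a weaker inhibitor), compound 1 gives 33800 nM. Compound 2 gives 17000 nM, within the scatter of compound 1. For compound 3 this assay reports only a limit, > 100000 nM. Going by the values given here, no two measured compounds differ in a single place, so no measured step is available.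

Compound 4 `O[C@@H](c1ccccc1)[C@H]1CO[C@H](c2ccccc2)[C@@H](C/C=C/c2cccnc2)C1` differs from compound 1 by pyridin-3-yl in place of pyridin-2-yl on a double-bonded chain carbon bound to a double-bonded chain carbon. A shift of the ring nitrogen alone usually gives no change beyond the scatter in this assay, in either direction. Compound 4 is therefore expected near compound 1, at 30000 nM (range 12000 nM to 80000 nM), meaning an estimated step of a 1.1-fold lower number from compound 1 to compound 4 (0.05 log units; within the scatter).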

Compound 4, half-maximal inhibitory concentration: > 100000 nM
Compound 4 was reported as a limit (the forecaster's own chance of this, stated with the estimate: 10%); at least 3.3-fold (0.52 log units) between middle value and limit.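

In this assay, the position on a double-bonded chain carbon bound to a double-bonded chain carbon proves sensitive to the place of the ring nitrogen alone: pyridin-3-yl in place of pyridin-2-yl gives an at least 2.9-fold higher number from compound 1 to compound 4 (0.47 log units; beyond the scatter). Going by these compounds alone, this is the first single-place step, and the two groups match in every count computed for them. The step is only a lower bound, as compound 4 is reported as a limit: the limit of > 100000 nM in this assay, at which 2 of the 4 values shown sit.

On these data alone, the full size of the step stays open. As far as these compounds go, whether pyridin-4-yl or an aminomethyl group at this place would retain the cytotoxicity of compound 1 also stays open.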